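This account rests on a few compounds, and the source may have more. Where it says the series, first, only, none or still open, it means among the compounds named here.

Of the compounds shown here, two have been measured in a functional assay on MCF7 cells (Homo sapiens) for inhibition, read by MTT assay, with a stated time of 72 h; a higher number here means a weaker inhibitor, a lower number a stronger inhibitor. Compound 1, `Cc1cc(Nc2cc(-c3ccccc3)[nH]n2)n2nc(SCCc3ccccc3)nc2n1`, gives 2700 nM, the lowest of the two numbers. Compound 2, `Cc1cc(Nc2ccn(Cc3ccccc3)n2)n2nc(SCc3ccc(Br)cc3)nc2n1`, gives 15800 nM, a weaker result that lies beyond the scatter from compound 1. Compound 3, `COc1ccc(CSc2nc3nc(C)cc(Nc4cc(-c5ccccc5)[nH]n4)n3n2)cc1`, is not yet measured; it differs from compound 1 by 4-methoxyphenyl in place of benzyl on a saturated chain carbon bound to a sulfur. Going by the values given here, no measured pair shows this change alone, so the expected step is judged from compound 1 only. Compound 3 is expected to land close to compound 1, with an estimated step of a 1.3-fold higher number from compound 1 to compound 3 (0.11 log units; within the scatter) no larger than the scatter. The estimate for compound 3 is 3500 nM, within 1200 nM to 10000 nM.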

Compound 3, half-maximal inhibitory concentration: 4020 nM
Compound 3: the middle estimate sits 1.1-fold (0.06 log units) below what was measured; measured number inside the range.
By their numbers in this assay, from the lowest: compounds 1 and 3 (each within the scatter of the next); then compound 2.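

In this assay, exchanging phenethyl for 4-methoxybenzyl gives a 1.5-fold higher number from compound 1 to compound 3 (0.17 log units; within the scatter). This position therefore accepts this exchange, which brings in one oxygen and one hydrogen-bond acceptor, without a clear change in the number. Nothing measured here speaks to the reason for this result.

This single pair leaves open how the same position responds to groups of a different kind, such as an amine or a carboxylic acid.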